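Swapping dichlorophenyl for hydroxyphenyl on a fused core

The compounds below may be only part of what the source reports. "The series", "measured", "known", "first", "only" and "open" are said of these compounds alone.

Measured compounds:
Compound 1 `Cn1cnc2c(N3CCCCC3)nc(-c3ccccc3O)nc21`: 50.5%
Compound 2 `CN1CCN(c2nc(-c3cccc(O)c3)nc3c2ncn3C)CC1`: 27.1%
Compound 3 `CN1CCN(c2nc(-c3ccc(Cl)c(Cl)c3)nc3c2ncn3C)CC1`: 65.2%

Among the measured compounds shown here, in an assay on cells for displacement of a labelled ligand from adenosine receptor A1 (Homo sapiens), read by scintillation counting and radioligand binding, with a stated time of 60 min, tested at 10 uM (a lower number here means less inhibition, a higher number more inhibition at the concentration tested (going by the name of the read-out)), compound 3 gives the highest of the three numbers; compound 1 sits a number 38.1 percentage points higher from compound 2 to compound 3 (beyond the scatter) is the only measured step on the same position, and compound 1 stands closest to compound 3, while compound 2 lies furthest away. Compound 4 `CN1CCN(c2nc(-c3ccccc3O)nc3c2ncn3C)CC1` has not yet been measured. It differs from compound 3 in one place: 2-hydroxyphenyl in place of 3,4-dichlorophenyl on an aromatic carbon.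

For the measured compounds named here, the measured step bearing on this change is the one from compound 2 to compound 3, where 3,4-dichlorophenyl replaced a hydroxyphenyl and the inhibition rose by a large amount. Compound 4 reverses that kind of exchange, so a drop is expected. Compound 1, which also carries 2-hydroxyphenyl on a related core, gives 50.5%, which tempers how far the fall might go. Compound 4 is therefore expected to give 35%, with a range from 15% to 55%, corresponding to an estimated step of a number 30.2 percentage points lower from compound 3 to compound 4 (beyond the scatter).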

Compound 4, a percentage reported as inhibition, at one concentration (the size of the read-out at that concentration, not a potency): > 80%
Compound 4: no number, only a limit (the forecaster's own chance of this, stated with the estimate: 0%); middle value at least 45 percentage points from the limit.
By their numbers in this assay, from the lowest: compound 2; then compound 1; then compound 3. At a limit, above all of these: compound 4.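

In this assay compound 4 gives > 80%, which is a limit of the assay and not a number. On the aromatic carbon between two ring nitrogen atoms, the earlier drop with a hydroxyphenyl group does not hold for every hydroxyphenyl: 2-hydroxyphenyl in place of 3-hydroxyphenyl gives a number at least 52.9 percentage points higher from compound 2 to compound 4 (beyond the scatter), and 2-hydroxyphenyl in place of 3,4-dichlorophenyl gives a number at least 14.8 percentage points higher from compound 3 to compound 4 (beyond the scatter). With 2-hydroxyphenyl kept, 4-methylpiperazin-1-yl in place of piperidin-1-yl gives a number at least 29.5 percentage points higher from compound 1 to compound 4 (beyond the scatter), so the change in the other group also matters.

On these data alone, the true size of these steps remains open, since a limit sets only their smallest possible size. Also open, as far as these compounds go, is whether 2-methoxyphenyl or 2-aminophenyl in place of 2-hydroxyphenyl would hold inhibition at this level.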